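Aryl replacement at the pyrimidine ring: from thiazolyl to benzothiophenyl

The source may report more compounds than this note shows. Statements on the series, on what has been measured and on what is new or still open speak of the compounds shown alone.

Two members of the series have numbers in a functional assay on Jurkat cells for inhibition of nuclear factor NF-kappa-B complex (Homo sapiens); a lower number here means a stronger inhibitor, a higher number a weaker inhibitor. Compound 1 `CCOC(=O)c1cnc(C)nc1NN1C(=O)C=C(C)C1=O` gives 16000 nM. Among the compounds with values here, compound 2 `CCOC(=O)c1cnc(-c2csc(C)n2)nc1NN1C(=O)C=C(C)C1=O` gives 8000 nM; the step of a 2.0-fold lower number from compound 1 to compound 2 (0.30 log units; within the scatter) is the only measured step, so compound 2 and compound 1 cannot be separated by their numbers in this assay. Compound 3 `CCOC(=O)c1cnc(-c2cc3ccccc3s2)nc1NN1C(=O)C=C(C)C1=O` is not yet measured. Its difference from compound 2: 1-benzothiophen-2-yl in place of 2-methyl-1,3-thiazol-4-yl on an aromatic carbon. Within the data shown here, the one measured step bears on this only loosely, since it exchanged a methyl for the 2-methyl-1,3-thiazol-4-yl group at the same place and stayed within the scatter. Nothing measured supports a step beyond the scatter in this assay for the exchange of one aryl group for another at this place. Compound 3 is therefore expected at 6000 nM, within 2000 nM to 20000 nM, a step of a 1.3-fold lower number from compound 2 to compound 3 (0.12 log units; within the scatter) that is itself expected to lie inside the scatter.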

Compound 3, half-maximal inhibitory concentration: 4000 nM
The estimate for compound 3 lay 1.5-fold (0.18 log units) above the measured number, and the stated range covers the measured number.
By their numbers in this assay, from the lowest: compounds 3, 2 and 1 (each within the scatter of the next, the first and the last beyond it).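

In this assay the exchange of 2-methyl-1,3-thiazol-4-yl for 1-benzothiophen-2-yl gives a 2.0-fold lower number from compound 2 to compound 3 (0.30 log units; within the scatter), so these two aryl groups cannot be separated at this place, even though the entering group carries an added six-membered aromatic ring of carbon only. Against the methyl group the picture changes: a 4.0-fold lower number from compound 1 to compound 3 (0.60 log units; beyond the scatter) is the first step at this position to pass beyond the scatter, though it remains modest, and compound 2 lies within the scatter of both neighbours. No measurement is available that accounts for this step.

Open, as far as these compounds go, is whether an amine or a longer alkyl chain at this place would read like the methyl group or like the aryl groups. Also open, from the compounds shown here alone, is how a carboxylic acid in place of the ethoxycarbonyl group would behave alongside 1-benzothiophen-2-yl.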